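Benzyl Substituent Change on a Pyrazole Amide Series

The source may hold more compounds than are shown below. What is called first, only, known or untested is meant among the compounds shown, and "the series" means these compounds.

Measured compounds:
compound 1, `CC1(C)c2[nH]nc(NC(=O)c3ccccc3)c2CN1Cc1ccccc1`, gives 1240 nM in an assay on Sf21 cells for inhibition of high affinity nerve growth factor receptor (Homo sapiens), read by HTRF, with a stated time of 30 min, in the presence of a further agent that is not named here; a higher number here means a weaker inhibitor, a lower number a stronger inhibitor
compound 2, `CC1(C)c2[nH]nc(NC(=O)c3ccccc3)c2CN1Cc1cccc(Br)c1`, gives 940 nM in this assay

In this assay compound 2 holds the lowest of the two numbers, though the step of a 1.3-fold lower number from compound 1 to compound 2 (0.12 log units; within the scatter) lies within the scatter. Compound 3, `CC1(C)c2[nH]nc(NC(=O)c3ccccc3)c2CN1Cc1ccc(F)c(F)c1`, is not yet measured. It differs from compound 2 as follows: 3,4-difluorophenyl in place of 3-bromophenyl on a saturated chain carbon bound to an amine nitrogen in a ring. Among the compounds with values here, the only measured step, a 1.3-fold lower number from compound 1 to compound 2 (0.12 log units; within the scatter), stayed within the scatter. That step also alters the same aromatic ring. No step beyond the scatter is therefore expected; compound 3 is estimated at 1000 nM, between 400 nM and 2500 nM, a step of a 1.1-fold higher number from compound 2 to compound 3 (0.03 log units; within the scatter).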

Compound 3, half-maximal inhibitory concentration: 680 nM
For compound 3 the middle estimate is 1.5-fold (0.17 log units) above the measured one; the range from low to high includes it.
By their numbers in this assay, from the lowest: compounds 3, 2 and 1 (each within the scatter of the next).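

In this assay, 3,4-difluorophenyl in place of 3-bromophenyl gives a 1.4-fold lower number from compound 2 to compound 3 (0.14 log units; within the scatter) and in place of phenyl gives a 1.8-fold lower number from compound 1 to compound 3 (0.26 log units; within the scatter) on the same saturated chain carbon bound to an amine nitrogen in a ring. A ring carrying two fluorines therefore stays within the scatter of both earlier compounds, so all three substituted or unsubstituted rings at this position read alike. Nothing available accounts for these numbers. Going by these compounds, whether a carboxylic acid or an amine on this aromatic ring, or a longer chain in place of the benzyl group, would give a step beyond the scatter remains open.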